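Moving the Pyridine Nitrogen: From Compound 2 to Compound 3

The source may hold more compounds than are shown below. What is called first, only, known or untested is meant among the compounds shown, and "the series" means these compounds.

Measured so far:
Compound 1 `CS(=O)(=O)c1ccc2nc(-c3ccc(-c4ccccc4)cc3)[nH]c2c1` gives 20 nM in an assay on isolated protein for inhibition of acyl-CoA desaturase 1 (Rattus norvegicus); a higher number here means a weaker inhibitor, a lower number a stronger inhibitor.
Compound 2 `CS(=O)(=O)c1ccc2nc(-c3ccc(-c4ccncc4)cc3)[nH]c2c1` gives 2470 nM in this assay.

Compound 2 has the highest number of the two, so it is the weaker inhibitor; the step of a 120-fold higher number from compound 1 to compound 2 (2.09 log units; beyond the scatter) is large and well beyond the scatter. The unmeasured compound 3 `CS(=O)(=O)c1ccc2nc(-c3ccc(-c4cccnc4)cc3)[nH]c2c1` differs from compound 2 only in the position of the nitrogen within the outer ring: pyridin-3-yl in place of pyridin-4-yl on an aromatic carbon. Within the data shown here, no measured step covers this particular change; the only step known, from compound 1 to compound 2, compares a ring with no nitrogen to one with nitrogen, which is a different question. The expectation therefore rests on compound 2 alone, with wide uncertainty. Compound 3 is expected to stay in the weak range of compound 2, though the estimate allows some movement toward compound 1, giving an expected step of a 2.5-fold lower number from compound 2 to compound 3 (0.39 log units; beyond the scatter). The estimate for compound 3 is 1000 nM, with a range from 200 nM to 5000 nM.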

Compound 3, half-maximal inhibitory concentration: 425 nM
Beside the measured number, compound 3's estimate is 2.4-fold (0.37 log units) above it; the range from low to high includes it.
By their numbers in this assay, from the lowest: compound 1; then compound 3; then compound 2.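

The position of the nitrogen within the outer ring matters on its own: with the same atoms joined differently, pyridin-3-yl in place of pyridin-4-yl gives a 5.8-fold lower number from compound 2 to compound 3 (0.76 log units; beyond the scatter) in this assay. This recovers only part of what was lost, since replacing phenyl with pyridin-3-yl still gives a 21-fold higher number from compound 1 to compound 3 (1.33 log units; beyond the scatter), so the ring without nitrogen keeps the lowest number of the three compounds. Nothing available here accounts for the difference between the two nitrogen positions.

The compounds shown leave open how pyridin-2-yl, the remaining single-nitrogen arrangement, would compare, and whether a ring with two nitrogens, such as pyrimidin-5-yl, would follow either pyridine. They also leave open what a methoxy group or an amine on the outer phenyl ring of compound 1 would do.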